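Opening the aryl-pyrrolidine: propylaminomethyl in place of pyrrolidinyl

The source may hold more compounds than are shown below. What is called first, only, known or untested is meant among the compounds shown, and "the series" means these compounds.

Compound 1 `COc1ccccc1-c1cc(C2CCNC2)ccc1Cl` is the anchor of this small set. In an assay on isolated protein for binding affinity to 5-hydroxytryptamine receptor 1D (Homo sapiens) (on this read-out higher numbers stand for weaker inhibition and lower numbers for stronger inhibition), compound 1 gives 3.4 nM, the lowest number among the three measured compounds. Compound 2 `COc1ccccc1-c1cc(C2CCN(C)C2)ccc1Cl` carries a methyl on the ring nitrogen and in this assay compound 2 gives 19 nM; the step is a 5.6-fold higher number from compound 1 to compound 2 (0.75 log units; beyond the scatter). Compound 3 `CCCCNCc1ccc(Cl)c(-c2ccccc2OC)c1` replaces the pyrrolidine with an open chain and in this assay compound 3 gives 2000 nM; the step is a 590-fold higher number from compound 1 to compound 3 (2.77 log units; beyond the scatter), and from the methylated ring it is a 110-fold higher number from compound 2 to compound 3 (2.02 log units; beyond the scatter).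

Compound 4 `CCCNCc1ccc(Cl)c(-c2ccccc2OC)c1` differs from compound 1 by (propylamino)methyl in place of pyrrolidin-3-yl on an aromatic carbon. Among the compounds with values here, the change most directly comparable is the one to compound 3, where an open-chain amine of the same kind, one carbon longer, cost a large step (a 590-fold higher number from compound 1 to compound 3 (2.77 log units; beyond the scatter)). Within the data shown here, no measured pair isolates the shortening of the chain by one carbon, so the chain length itself cannot be weighed from these data. The expectation is therefore a large step up in this assay, a 440-fold higher number from compound 1 to compound 4 (2.64 log units; beyond the scatter), of roughly the size seen for compound 3 because of a 590-fold higher number from compound 1 to compound 3 (2.77 log units; beyond the scatter). Compound 4 is estimated at 1500 nM, within a range of 400 nM to 6000 nM.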

Compound 4, inhibition constant: 220 nM
Compound 4: middle estimate off by 6.8-fold (0.83 log units), on the high side, outside the stated range (below it).
By their numbers in this assay, from the lowest: compound 1; then compound 2; then compound 4; then compound 3.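

Within the open-chain amines, the length of the chain matters in this assay: (propylamino)methyl gives a lower number than its butyl homologue (a 9.1-fold lower number from compound 3 to compound 4 (0.96 log units; beyond the scatter)), a comparison that compounds 1 to 3 alone could not provide. Shortening the chain recovers only part of the gap to the ring, which remains large against the unsubstituted pyrrolidine (a 65-fold higher number from compound 1 to compound 4 (1.81 log units; beyond the scatter)) and against its N-methyl form (a 12-fold higher number from compound 2 to compound 4 (1.06 log units; beyond the scatter)), even though pyrrolidin-3-yl and (propylamino)methyl have the same counts of heavy atoms, hydrogen-bond donors and hydrogen-bond acceptors and differ in the ring. Nothing at hand explains either the effect of chain length or the advantage of the ring at this position.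

Two open-chain points cannot tell whether (ethylamino)methyl or (methylamino)methyl would lower the number further, or whether a longer chain such as (pentylamino)methyl would raise it again. On these data alone, it also remains open whether a methyl on the nitrogen of the (propylamino)methyl group would raise the number as it does on the pyrrolidine, and how a piperidine ring would compare with pyrrolidin-3-yl.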